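The source may hold more compounds than are shown below. What is called first, only, known or untested is meant among the compounds shown, and "the series" means these compounds.

Measured so far in a functional assay on MCF7 cells (Homo sapiens) for inhibition, read by sulforhodamine B assay, with a stated time of 24 h; a higher number here means a weaker inhibitor, a lower number a stronger inhibitor

Compound 1 `Cc1ccc(C(=O)/C=C/c2ccc(C(=O)O)cc2)o1` gives 19700 nM
Compound 2 `O=C(O)c1ccc(/C=C/C(=O)c2ccccc2)cc1` gives 11900 nM
Compound 3 `COc1ccc(C(=O)/C=C/c2ccc(C(=O)O)cc2)cc1[N+](=O)[O-]` gives 9520 nM

Compound 3 stands level with compound 2 within the scatter, and its number is lower than that of compound 1 by a gap beyond the scatter. Compound 4 `COc1ccc(C(=O)/C=C/c2ccc(C(=O)O)cc2)cc1OC` differs from compound 3 by methoxy in place of nitro on an aromatic carbon, ortho to a methoxy group and meta to a large group (methoxy in place of nitro on an aromatic carbon). Within the data shown here, no measured step covers this exchange directly. Among the measured compounds shown here, the only step between measured compounds (a 1.7-fold lower number from compound 1 to compound 2 (0.22 log units; within the scatter)) concerns another part of the structure, phenyl in place of 5-methylfuran-2-yl on a carbonyl carbon, and it stays within the scatter. The three values together span little more than the scatter. No step beyond the scatter is therefore expected in this assay and these data favour no direction. The expected change is small (a 1.1-fold higher number from compound 3 to compound 4 (0.02 log units; within the scatter)) and stays within the scatter. For compound 4 the estimated value is 10000 nM with an expected range from 4500 nM to 22000 nM and the measurement is still to come.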

Compound 4, half-maximal inhibitory concentration: 8880 nM
Estimate against measurement, compound 4: 1.1-fold (0.05 log units) above, and the stated range covers the measured number.
By their numbers in this assay, from the lowest: compounds 4, 3, 2 and 1 (each within the scatter of the next, the first and the last beyond it).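

In this assay, among these compounds, the step at the aromatic carbon ortho to a methoxy group and meta to a large group is a 1.1-fold lower number from compound 3 to compound 4 (0.03 log units; within the scatter), the only reading at this position, since the earlier step concerned the group on the carbonyl carbon. The exchange is not a trivial one on paper: nitro, with 3 heavy atoms, a double bond and 2 hydrogen-bond acceptors, gives way to methoxy, with 2 heavy atoms and 1 hydrogen-bond acceptor, yet the assay does not separate compound 3 from compound 4, so these differences in group leave no mark on the number at this position. Nothing measured here says why the two groups read alike.

Two groups at one position cannot show whether this site is indifferent to substitution in general, and an amine, a hydroxyl group or a longer chain such as butoxy could still read differently there. From the compounds shown here alone, it also stays open whether the same exchange would read alike without the neighbouring methoxy group, or with another group in its place.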